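Thiourea series: fluoro and ethoxy variants, melanoma cell growth

This account rests on a few compounds, and the source may have more. Where it says the series, first, only, none or still open, it means among the compounds named here.

All values below come from a functional assay on B16-F10 cells (Mus musculus) for cytotoxicity, read by MTT assay, with a stated time of 48 h; on this read-out higher numbers stand for weaker inhibition and lower numbers for stronger inhibition.

Compound 1, `S=C(Nc1ccccc1)Nc1nc2ccccc2s1`: in this assay compound 1 gives only a limit, > 50000 nM.
Compound 2, `CCOc1ccc2nc(NC(=S)Nc3ccccc3)sc2c1`: in this assay compound 2 gives only a limit, > 50000 nM.
Compound 3, `Fc1ccc2nc(NC(=S)Nc3ccccc3)sc2c1`: in this assay compound 3 gives only a limit, > 50000 nM.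

Compound 2 and compound 3 each differ from compound 1 in one place. The two cores differ by ethoxy in place of hydrogen on an aromatic carbon. Compound 3 carries fluoro in place of hydrogen on an aromatic carbon. The steps a step that the two limits leave unreadable from compound 1 to compound 2, a step that the two limits leave unreadable from compound 1 to compound 3 and a step that the two limits leave unreadable from compound 2 to compound 3 cannot be sized, due to the limit of > 50000 nM in this assay, at which 3 of the 3 values shown sit.

The unmeasured compound 4, `CCOc1ccc2nc(NC(=S)Nc3ccc(F)cc3)sc2c1`, differs from compound 2 by fluoro in place of hydrogen on an aromatic carbon. This is the same kind of change as that from compound 1 to compound 3, not the same change: in compound 3 the fluoro sits on a six-membered aromatic ring of carbon only, part of a fused or bridged system of two rings, meta to a fused ring and para to a fused ring, while in compound 4 it sits on a six-membered aromatic ring of carbon only, para to a large group. The earlier step of this kind is a step that the two limits leave unreadable from compound 1 to compound 3, and no readable size comes from it.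

For compound 4 the expected step is a step that the limit leaves unreadable from compound 2 to compound 4, resting on compound 2 at > 50000 nM and on the fact that compound 3 at > 50000 nM shows no gain from a fluoro. Compound 4 is therefore estimated at 60000 nM, expected between 20000 nM and 200000 nM, most likely again as a limit.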

Compound 4, half-maximal inhibitory concentration: > 50000 nM
Compound 4 gave a limit, no number; the forecaster's own chance of this, stated with the estimate: 80%; the middle value lies beyond the limit too.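

No new step can be read: compound 2 and compound 4 both give only limits in this assay, so the change from phenyl to 4-fluorophenyl cannot be sized, due to the limit of > 50000 nM in this assay, at which 4 of the 4 values shown sit.

The compounds shown leave open whether fluoro or ethoxy on any of these positions changes the read-out at all, as none of the four compounds has a value that is a number.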